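The compounds below may be only part of what the source reports. "The series", "measured", "known", "first", "only" and "open" are said of these compounds alone.

Measured compounds in an assay on brain for inhibition of Fatty-acid amide hydrolase 1 (Rattus norvegicus), read by scintillation counting, with a stated time of 10 min; a higher number here means a weaker inhibitor, a lower number a stronger inhibitor:

compound 1 `CC(C)Cc1ccc(C(C)C(=O)NCc2cccc(C(F)(F)F)c2)cc1` gives 28000 nM
compound 2 `COc1ccc(CNC(=O)C(C)c2ccc(CC(C)C)cc2)cc1O` gives 18000 nM
compound 3 `CC(C)Cc1ccc(C(C)C(=O)N2CCN(c3cccc(Cl)c3)CC2)cc1` gives 1700 nM

Among these three, compound 3 stands lowest in this assay, and both other numbers lie well beyond the scatter of it: compound 2 is nearest, compound 1 furthest. Among the measured compounds shown here, compound 3 differs from the other two in the amide part, which is a ring amine rather than a benzylic amide, but no pair of the measured compounds differs in one place only, so no single step between them can be read off.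

Compound 4 `Cc1cccc(N2CCN(C(=O)C(C)c3ccc(CC(C)C)cc3)CC2)c1C` follows from compound 3 by one change: 2,3-dimethylphenyl in place of 3-chlorophenyl on an amine nitrogen in a ring. The shared core of compound 3 is kept. For the measured compounds named here, the data hold no measured pair that changes a group on this ring nitrogen, so the size of the step has no precedent here. He expects the step from compound 3 to compound 4 to stay within the scatter or near its edge, in either direction, a 1.3-fold higher number from compound 3 to compound 4 (0.11 log units; within the scatter). For compound 4 in this assay his estimate is 2200 nM, with a range from 600 nM to 8000 nM.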

Compound 4, half-maximal inhibitory concentration: 1700 nM
Estimate against measurement, compound 4: 1.3-fold (0.11 log units) above; measured number inside the range.
By their numbers in this assay, from the lowest: compounds 3 and 4 (each within the scatter of the next); then compounds 2 and 1 (each within the scatter of the next).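

In this assay, among the compounds shown here, 2,3-dimethylphenyl in place of 3-chlorophenyl on the amine nitrogen in a ring gives no change at the digits printed from compound 3 to compound 4 (within the scatter) and is the first step read at this position. It shows that the number can hold within the scatter when the chlorine leaves and two methyl groups enter, with one more heavy atom and the same count of hydrogen-bond donors and acceptors. Nothing at hand explains this outcome.

The compounds shown carry only a substituted phenyl ring on this nitrogen, so they leave open how a benzyl group, or a phenyl ring bearing a carboxylic acid or an amine, would read. They also leave open whether an unsubstituted phenyl ring would give a number within the scatter of these two.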